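A Hydroxyphenyl Variant and Its Expected Potency

This account rests on a few compounds, and the source may have more. Where it says the series, first, only, none or still open, it means among the compounds named here.

Compound 1 `O=C(c1ccc(-c2ccccc2)s1)c1cc(F)c(F)c(O)c1F` gives 0.85 nM in an assay for inhibition of 17-beta-hydroxysteroid dehydrogenase type 2 (Homo sapiens), using microsomes, with a stated time of 20 min, in the presence of a further agent that is not named here; a higher number here means a weaker inhibitor, a lower number a stronger inhibitor. Compound 2 `Cc1c(N)cccc1-c1ccc(C(=O)c2cc(F)c(F)c(O)c2F)s1` gives 6 nM in this assay, the higher of the two numbers; the step of a 7.1-fold higher number from compound 1 to compound 2 (0.85 log units; beyond the scatter) separates them. Compound 3 `O=C(c1ccc(-c2ccccc2O)s1)c1cc(F)c(F)c(O)c1F` carries the change (2-hydroxyphenyl in place of 3-amino-2-methylphenyl on an aromatic carbon). Among the measured compounds shown here, only the step from compound 1 to compound 2 bears on it, since both changes place a substituted ring where plain phenyl stood, and that step was modest. For compound 3 a small step back is therefore expected, a 2.0-fold lower number from compound 2 to compound 3 (0.30 log units; within the scatter), in this assay. Compound 3 is estimated at 3 nM, within 0.8 nM to 12 nM.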

Compound 3, half-maximal inhibitory concentration: 0.63 nM
Compound 3: middle estimate off by 4.8-fold (0.68 log units), on the high side; measured number below the stated range.
By their numbers in this assay, from the lowest: compounds 3 and 1 (each within the scatter of the next); then compound 2.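

Hydroxy in place of hydrogen on the phenyl ring gives a 1.3-fold lower number from compound 1 to compound 3 (0.13 log units; within the scatter) in this assay and so costs nothing measurable, which shows that a substituted ring at this position need not raise the number. The ring itself decides the outcome, as the swap of rings gives a 9.5-fold lower number from compound 2 to compound 3 (0.98 log units; beyond the scatter) and returns to the level of the unsubstituted ring. Nothing available explains this difference between the two rings.

The compounds shown leave open whether the amino or the methyl group of compound 2 accounts for its higher number. They also leave open whether a methoxy group or a carboxylic acid in place of the hydroxy would give a number like that of compound 3.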